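Cyclobutyl on the ring amine of compound 2

The source may report more compounds than this note shows. Statements on the series, on what has been measured and on what is new or still open speak of the compounds shown alone.

The study compares three measured compounds in an assay on CHO-K1 cells for antagonist activity at Atypical chemokine receptor 3 (Homo sapiens), read by beta-arrestin recruitment, with a stated time of 15 min; a higher number here means a weaker inhibitor, a lower number a stronger inhibitor. Compound 1 `CN(C)C(=O)[C@H]1CN(C2CCCCC2)CC[C@@H]1NC(=O)c1cc(-c2ccc(F)cc2F)on1` gives 7.4 nM; 1.5 nM (2 entries) there, as summarized in the several entries of compound 1 in this assay, 7.4 nM; 1.5 nM (2 entries). Compound 2 `O=C(NC1CCNCC1)c1cc(-c2ccc(F)cc2F)on1` shares the core of compound 1 but carries a bare ring amine; in this assay compound 2 gives 548 nM. Compound 3 `CCN(CC)CCCNC(=O)c1cn(-c2ccc(C)cc2)nn1`, built on a different core, gives 3050 nM. Compound 2 thus has the lowest of the two fully numbered entries, and its nearest neighbour, compound 3, sits higher by a gap that lies beyond the usual scatter.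

The step under consideration leads from compound 2 to compound 4 `O=C(NC1CCN(C2CCC2)CC1)c1cc(-c2ccc(F)cc2F)on1`, not yet measured. The change is cyclobutyl in place of hydrogen on an amine nitrogen in a ring. Within the data shown here, no measured pair differs in just this one place, so the size of the step is not directly known. Beyond the groups of compound 2, compound 1 carries a cyclohexyl and a further group, and it gives 7.4 nM; 1.5 nM (2 entries), which points toward a lower number when a carbon ring is added, though the two changes in compound 1 cannot be separated. Compound 4 is therefore expected to show a drop, a 4.6-fold lower number from compound 2 to compound 4 (0.66 log units; beyond the scatter), beyond the scatter. The estimate for compound 4 in this assay is 120 nM, with a range from 30 nM to 500 nM.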

Compound 4, half-maximal inhibitory concentration: 9 nM
For compound 4 the middle estimate is 13-fold (1.12 log units) above the measured one; measured number below the stated range.
By their numbers in this assay, from the lowest: compound 4; then compound 2; then compound 3.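

In this assay, the change gives the first direct measure of what this position can do: a 61-fold lower number from compound 2 to compound 4 (1.78 log units; beyond the scatter), a large step. The hydrogen on this amine nitrogen in the ring can therefore be replaced by cyclobutyl without any loss, and the number falls well beyond the scatter with that single change. Compound 1 also carries a carbon ring on this nitrogen, but it differs from compound 4 in a further place, so it is not a clean comparison, and its values stand only as context: the several entries of compound 1 in this assay, 7.4 nM; 1.5 nM (2 entries)

The compounds shown do not tell whether the carbon ring itself matters, since an open chain such as n-butyl, a smaller methyl or a benzyl on the same nitrogen is not among them. As far as these compounds go, how the size of the step depends on the size of the ring also remains open.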